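Stereo swap from compound 3 to compound 4

This account rests on a few compounds, and the source may have more. Where it says the series, first, only, none or still open, it means among the compounds named here.

Measured so far in an ADME assay on MDCK cells (Canis lupus familiaris) for permeability, in the apical to basolateral direction (a higher number here means that the compound crosses the layer faster, a lower number that the compound crosses the layer more slowly), for three compounds:
- compound 1 `C[C@H](Nc1nccc(Nc2cc(C3CC3)[nH]n2)n1)c1ccc2[nH]ccc2n1` gives 4.3 10^-6 cm/s
- compound 2 `C[C@H](Nc1nccc(Nc2cc(C3CC3)[nH]n2)n1)c1cc2cc[nH]c2cn1` gives 0.9 10^-6 cm/s
- compound 3 `C[C@H](Nc1nccc(Nc2cc([C@H]3C[C@@H]3F)[nH]n2)n1)c1ccc2[nH]ccc2n1` gives 3.7 10^-6 cm/s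

Compound 3 stands within the scatter of compound 1 and beyond the scatter from compound 2. Compound 4 `C[C@H](Nc1nccc(Nc2cc([C@@H]3C[C@H]3F)[nH]n2)n1)c1ccc2[nH]ccc2n1` relates to compound 3 as follows: the two compounds have the same atoms and bonds and differ only in configuration as drawn: 2 of 3 stereo elements differ; a stereocentre at a saturated ring carbon is drawn R in compound 3 and S in compound 4; a stereocentre at a saturated ring carbon is drawn S in compound 3 and R in compound 4 and nothing else differs. The closest measured step is a 1.2-fold lower number from compound 1 to compound 3 (0.07 log units; within the scatter) for fluoro in place of hydrogen on a saturated ring carbon, within the scatter. For the measured compounds named here, the larger 4.8-fold lower number from compound 1 to compound 2 (0.68 log units; beyond the scatter) swaps a different group, and no measured pair tests configuration alone. In this assay no change beyond the scatter is expected, so the expected no change at the digits printed from compound 3 to compound 4 (within the scatter) remains small. Compound 4 is estimated at 3.7 10^-6 cm/s with an expected range from 2.1 10^-6 cm/s to 6.2 10^-6 cm/s in this read-out.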

Compound 4, apparent permeability: 4.2 10^-6 cm/s
Estimate against measurement, compound 4: 1.1-fold (0.06 log units) below, and the stated range covers the measured number.
By their numbers in this assay, from the lowest: compound 2; then compounds 3, 4 and 1 (each within the scatter of the next).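

In this assay, configuration at the two saturated ring carbons is now tested alone and gives a 1.1-fold higher number from compound 3 to compound 4 (0.06 log units; within the scatter). With a 1.0-fold lower number from compound 1 to compound 4 (0.01 log units; within the scatter) alongside the earlier fluoro step, fluoro in place of hydrogen on a saturated ring carbon stays within the scatter of compound 1 in both drawn configurations. This pair isolates configuration from every other structural difference: the fact that compounds 3 and 4 differ only in the configuration as drawn. Open, going by these compounds, is whether an amine or trifluoromethyl on this saturated ring carbon would also stay within the scatter of compound 1. Also open, on these data alone, is whether fluoro gives the same reading on the core of compound 2.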